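A few compounds are considered here, and "the series" means these few. Any claim that something is new, unique, unknown or untested is made for them only; others in the source may bear on it.

Three compounds share one core and differ only in the halogen carried on the aromatic ring of the side arm. Compound 1 `COc1cc(/C=C2\CN(C)C/C(=C\c3ccc(F)cc3)C2=O)cc(OC)c1` gives 21900 nM in an ADME assay on L02 cells (Homo sapiens) for cytotoxicity, read by MTT assay, with a stated time of 24 h; on this read-out higher numbers stand for weaker inhibition and lower numbers for stronger inhibition. Compound 2 `COc1cc(/C=C2\CN(C)C/C(=C\c3ccc(Cl)cc3)C2=O)cc(OC)c1` gives 18900 nM in this assay, and compound 3 `COc1cc(/C=C2\CN(C)C/C(=C\c3ccc(Br)cc3)C2=O)cc(OC)c1` gives 21300 nM in this assay. Going by the values given here, the three steps among them, a 1.2-fold lower number from compound 1 to compound 2 (0.06 log units; within the scatter), a 1.0-fold lower number from compound 1 to compound 3 (0.01 log units; within the scatter) and a 1.1-fold higher number from compound 2 to compound 3 (0.05 log units; within the scatter), all lie within the scatter, so on these numbers compound 3 stands second highest of the three, with no compound set apart from the others.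

Compound 4 `COc1cc(/C=C2\CN(C)C/C(=C\c3ccc(Cl)cc3Cl)C2=O)cc(OC)c1` has not yet been measured. It differs from compound 3 in one place: 2,4-dichlorophenyl in place of 4-bromophenyl on a double-bonded chain carbon bound to a double-bonded ring carbon. Among the compounds with values here, the measured steps that bear on this change are the halogen exchanges on the same ring, and no measured pair shows a second chlorine entering that ring, so the added chlorine is uncovered by the data. Because the halogen exchanges a 1.0-fold lower number from compound 1 to compound 3 (0.01 log units; within the scatter) and a 1.1-fold higher number from compound 2 to compound 3 (0.05 log units; within the scatter) stayed within the scatter, compound 4 is expected to show a 1.1-fold lower number from compound 3 to compound 4 (0.03 log units; within the scatter). In this assay compound 4 is estimated at 20000 nM, with a range from 9000 nM to 45000 nM.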

Compound 4, half-maximal inhibitory concentration: 18800 nM
Estimate against measurement, compound 4: 1.1-fold (0.03 log units) above; measured number inside the range.
By their numbers in this assay, from the lowest: compounds 4, 2, 3 and 1 (each within the scatter of the next).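

The 2,4-dichlorophenyl arm settles what the halogen exchanges could not: with one more chlorine added to the ring, the step is a 1.0-fold lower number from compound 2 to compound 4 (0.00 log units; within the scatter) in this assay and so a second chlorine on this ring stays within the scatter. The same holds against the other two arms, with a 1.1-fold lower number from compound 3 to compound 4 (0.05 log units; within the scatter) and with a 1.2-fold lower number from compound 1 to compound 4 (0.07 log units; within the scatter), so none of the four compounds is set apart by what sits at this double-bonded chain carbon. Nothing measured here offers a reason for this result.

All four arms shown carry only halogens on the aromatic ring, so it stays open whether a methoxy group, an amine or a carboxylic acid there would leave this group of numbers. Going by these compounds, the shared core and the other arm are the same throughout, so what a change in either would do also stays open.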